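The source may hold more compounds than are shown below. What is called first, only, known or untested is meant among the compounds shown, and "the series" means these compounds.

Working notes on the series. In a functional assay on DU-145 cells (Homo sapiens) for inhibition, read by trypan blue exclusion, with a stated time of 96 h (a higher number here means a weaker inhibitor of growth, a lower number a stronger inhibitor of growth), compound 1 (`COc1cc(OC)c(/C=C(\C(=O)c2ccc(Br)cc2)S(=O)(=O)c2ccc(Br)cc2)c(OC)c1`) gives > 100000 nM, which is a limit and not a number. Compound 2 (`COc1cc(OC)c(/C=C(\C(=O)c2ccc(Cl)cc2)S(=O)(=O)c2ccc(Br)cc2)c(OC)c1`) gives > 100000 nM, also a limit. Compound 3 (`Cc1ccc(S(=O)(=O)/C(=C/c2ccc(F)cc2F)C(=O)c2ccc(Br)cc2)cc1`) gives > 100000 nM, again a limit. Compound 2 therefore has no numerical value, and it has no number to be ranked against: the limit of > 100000 nM in this assay, at which 3 of the 3 values shown sit.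

Compound 4 (`COc1cc(OC)c(/C=C(\C(=O)c2ccc(Cl)cc2)S(=O)(=O)c2ccc(C)cc2)c(OC)c1`) differs from compound 2 by methyl in place of bromo on an aromatic carbon, with methyl in place of bromo on an aromatic carbon, para to a large group. Among the measured compounds shown here, the only measured step is a step that the two limits leave unreadable from compound 1 to compound 2, with chloro in place of bromo, and it provides no size to carry over. For the measured compounds named here, no measured step covers the methyl for bromo change itself. The expectation rests on compound 2 at > 100000 nM and on the other two compounds sharing that limit in this assay.

No step beyond the scatter is expected, and no direction can be assigned. The expected change is a number no higher from compound 2 to compound 4 (the limit leaves the size open). For compound 4 the estimate is 100000 nM, with an expected range of 30000 nM to 200000 nM, and a report as a limit is the likeliest outcome.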

Compound 4, concentration for 50% growth inhibition: 25000 nM
For compound 4 the middle estimate is 4.0-fold (0.60 log units) above the measured one; the whole stated range lies above it.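

In this assay, among the compounds shown here, replacing 4-bromophenyl with 4-methylphenyl in the sulfonyl group gives an at least 4.0-fold lower number from compound 2 to compound 4 (0.60 log units; beyond the scatter), so a change at this place, para to a large group, can move the read-out in the shared core, which the earlier compounds could not show. Compound 2 gives > 100000 nM, which is a limit and not a number, so the step fixes only a minimum size. Compound 4 is the only one of the four compounds shown with a numerical value, and the others remain at the limit: the limit of > 100000 nM in this assay, at which 3 of the 4 values shown sit.

From the compounds shown here alone, the step between compound 1 and compound 2 cannot be read, so the effect of chloro against bromo on the other aromatic ring stays unknown. Also open, going by these compounds, is whether methoxy, an amine or a carboxylic acid at the place of the methyl group of compound 4 would give a lower or a higher number.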